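Compound 3 to compound 4: changing the amide substituent

This account rests on a few compounds, and the source may have more. Where it says the series, first, only, none or still open, it means among the compounds named here.

In an ADME assay on HepG2 2.2.15 cells (Homo sapiens) for cytotoxicity, read by MTT assay, with stated times of 48 h and 9 days (on this read-out lower numbers stand for higher toxicity in this test and higher numbers for lower toxicity in this test), compound 1 (`COc1ccc(CNC(=O)/C=C/c2coc3cc(O)ccc3c2=O)cc1`) reads 718000 nM and compound 2 (`COc1ccc2c(=O)c(/C=C/C(=O)NCc3ccc(C)cc3)coc2c1`) reads 257000 nM while compound 3 (`Cc1ccccc1NC(=O)/C=C/c1coc2cc(O)ccc2c1=O`) reads 374000 nM on the same scale. Compound 3 thus sits within the scatter of both other compounds. Compound 4 (`Cc1ccc(CNC(=O)/C=C/c2coc3cc(O)ccc3c2=O)cc1`) carries 4-methylbenzyl in place of 2-methylphenyl on an amide-type nitrogen. Among the compounds with values here, no measured pair differs in one place only, so no direct step is available to guide this change. The nearest guide is compound 2, which also carries 4-methylbenzyl: it reads 257000 nM in this assay and stays within the scatter of compound 3. The estimated step of a 1.1-fold higher number from compound 3 to compound 4 (0.06 log units; within the scatter) is therefore expected to stay within the scatter, with no clear direction. In this assay the estimate for compound 4 is 430000 nM with an expected range from 200000 nM to 850000 nM for this measurement.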

Compound 4, half-maximal cytotoxic concentration: 501000 nM
For compound 4 the middle estimate is 1.2-fold (0.07 log units) below the measured one; low and high end bracket the measured number.
By their numbers in this assay, from the lowest: compounds 2, 3, 4 and 1 (each within the scatter of the next, the first and the last beyond it).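

In this assay, 4-methylbenzyl in place of 2-methylphenyl on the amide-type nitrogen gives a 1.3-fold higher number from compound 3 to compound 4 (0.13 log units; within the scatter), so this whole-group exchange at this position leaves the reading within the scatter. Within the data shown here, compound 4 also supplies the first comparisons in one place elsewhere: hydrogen in place of methyl on an oxygen on an aromatic ring gives a 1.9-fold higher number from compound 2 to compound 4 (0.29 log units; within the scatter), and methyl in place of methoxy on an aromatic carbon gives a 1.4-fold lower number from compound 1 to compound 4 (0.16 log units; within the scatter), both within the scatter. No available evidence bears on these readings.

The exchange on the nitrogen alters the group as a whole, so the compounds shown do not separate the role of the methyl from that of the rest of the group. Also open, on these data alone, is how an amine or a carboxylic acid in place of that methyl, or a longer chain on the amide-type nitrogen, would read.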